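The source may report more compounds than this note shows. Statements on the series, on what has been measured and on what is new or still open speak of the compounds shown alone.

Of the compounds shown here, two that share one core have been tested in an assay on isolated protein for inhibition of long-chain fatty acid transport protein 1 (Homo sapiens); a lower number here means a stronger inhibitor, a higher number a weaker inhibitor. Compound 1 `CC/C(=N/OC)c1ccc2oc(CSc3nnc(CNc4ccccc4)n3CC)nc2c1` carries a methyl-oxime group on an aromatic carbon of the core. In this assay compound 1 gives > 1000 nM, which is a limit of the assay rather than a number. Compound 2 `CCC(O)c1ccc2oc(CSc3nnc(CNc4ccccc4)n3CC)nc2c1` carries a 1-hydroxypropyl group on that same aromatic carbon. In this assay compound 2 gives > 1000 nM, again a limit and not a number. The step that the two limits leave unreadable from compound 1 to compound 2 cannot be read, since both values sit at the limit (the limit of > 1000 nM in this assay, at which 2 of the 2 values shown sit). Compound 2 therefore stands at the limit, as does every value shown.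

Compound 3 `CC/C(=N/O)c1ccc2oc(CSc3nnc(CNc4ccccc4)n3CC)nc2c1` has not yet been measured. It differs from compound 2 by a group of 5 heavy atoms (3 carbon, 1 nitrogen, 1 oxygen; no ring) in place of a group of 4 heavy atoms (3 carbon, 1 oxygen; no ring), on an aromatic carbon. Within the data shown here, the only measured step, from compound 1 to compound 2, touches the same aromatic carbon but gives no readable size, so no direction and no size beyond the scatter can be drawn from it. Compound 1, with a related group at that carbon, also sits at the limit. Compound 3 is therefore expected to stay weak, most likely at the limit again, with an estimated step that the limit leaves unreadable from compound 2 to compound 3. The estimate for compound 3 is 3000 nM, in a range from 1000 nM to 20000 nM.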

Compound 3, half-maximal inhibitory concentration: 260 nM
For compound 3 the middle estimate is 12-fold (1.06 log units) above the measured one, outside the stated range (below it).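

Among these compounds, compound 3 gives the first readable steps at this aromatic carbon, and they show that the group held there matters in this assay: the oxime in place of 1-hydroxypropyl gives an at least 3.8-fold lower number from compound 2 to compound 3 (0.58 log units; beyond the scatter). A much smaller change also counts, as hydrogen in place of methyl on the oxime oxygen gives an at least 3.8-fold lower number from compound 1 to compound 3 (0.58 log units; beyond the scatter), so an oxime alone does not bring a readable value, for compound 1 carries a methylated one and stays at a limit. Both steps are minimum sizes, and the step between compound 1 and compound 2 cannot be read, with these two compounds at a limit: the limit of > 1000 nM in this assay, at which 2 of the 3 values shown sit.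

The compounds shown leave open how an amine or a carboxylic acid on this same aromatic carbon would compare with the oxime of compound 3. They also leave open whether a longer chain in the group, or an ethyl in place of the methyl on the oxime oxygen, would keep the number as low as in compound 3.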